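From 2-(piperidin-4-yl)ethyl to piperidin-4-yl on the shared core

This account rests on a few compounds, and the source may have more. Where it says the series, first, only, none or still open, it means among the compounds named here.

Of the compounds shown here, three with a shared core have been measured in an ADME assay on the whole organism (strain FVB) for pharmacokinetics, with Mus musculus as the target, read by LC-MS, at a dose of 30 mg/kg by the oral route; on this read-out lower numbers stand for lower exposure and higher numbers for higher exposure at the dose given. Compound 1 `NCCOc1ccc([C@H]2CC[C@]3(CC2)OOC2(O3)C3CC4CC(C3)CC2C4)cc1` gives 287 nM. Compound 2 `CC(C)(N)CCOc1ccc([C@H]2CC[C@]3(CC2)OOC2(O3)C3CC4CC(C3)CC2C4)cc1` gives 1050 nM. Compound 3 `c1cc([C@H]2CC[C@]3(CC2)OOC2(O3)C3CC4CC(C3)CC2C4)ccc1OCCC1CCNCC1` gives 1190 nM. Compound 3 therefore stands level with compound 2, as the step of a 1.1-fold higher number from compound 2 to compound 3 (0.05 log units; within the scatter) shows. Both stand clear of compound 1, with a 3.7-fold higher number from compound 1 to compound 2 (0.56 log units; beyond the scatter) and a 4.1-fold higher number from compound 1 to compound 3 (0.62 log units; beyond the scatter).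

The next compound is compound 4 `c1cc([C@H]2CC[C@]3(CC2)OOC2(O3)C3CC4CC(C3)CC2C4)ccc1OC1CCNCC1`, which has piperidin-4-yl in place of 2-(piperidin-4-yl)ethyl on an oxygen on an aromatic ring. For the measured compounds named here, no measured step makes this exact change, so the evidence is indirect. Going by the values given here, compound 4 keeps the piperidin-4-yl group of compound 3, and the step of a 4.1-fold higher number from compound 1 to compound 3 (0.62 log units; beyond the scatter) is the one that introduced that group. The step of a 1.1-fold higher number from compound 2 to compound 3 (0.05 log units; within the scatter) shows that two different groups on the same chain can give values within the scatter of each other. A change beyond the scatter in this assay is therefore not expected, though a small drop towards compound 1 remains possible. The expected result is a 1.4-fold lower number from compound 3 to compound 4 (0.15 log units; within the scatter), which stays within the scatter. For compound 4 the estimated value is 850 nM, with an expected range from 300 nM to 2200 nM.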

Compound 4, maximal plasma concentration: 810 nM
Beside the measured number, compound 4's estimate is 1.0-fold (0.02 log units) above it; low and high end bracket the measured number.
By their numbers in this assay, from the lowest: compound 1; then compounds 4, 2 and 3 (each within the scatter of the next).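

At the oxygen on the aromatic ring, the 2-(piperidin-4-yl)ethyl group of compound 3 can give way to the piperidin-4-yl group of compound 4, and this assay shows a 1.5-fold lower number from compound 3 to compound 4 (0.17 log units; within the scatter) for this change, so this read-out does not separate the two groups. The open-chain 3-amino-3-methylbutyl group of compound 2 also stands level with piperidin-4-yl, with a 1.3-fold lower number from compound 2 to compound 4 (0.11 log units; within the scatter) as the printed step, while the 2-aminoethyl group of compound 1 stays apart, with a 2.8-fold higher number from compound 1 to compound 4 (0.45 log units; beyond the scatter) for that change, so compounds 2, 3 and 4 form one level set clear of compound 1, and none of the four goes against this. Nothing shown here offers a measured reason for these numbers.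

What the compounds shown leave open is how a pyrrolidin-3-yl or azetidin-3-yl group on the same oxygen would stand against piperidin-4-yl. They also leave open whether a longer chain carrying the piperidine ring, or a carboxylic acid in place of the amine, would stay with this level set or fall towards compound 1.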